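The source may hold more compounds than are shown below. What is called first, only, known or untested is meant among the compounds shown, and "the series" means these compounds.

Measured so far in an assay on Prostate gland for inhibition of steroid 5-alpha-reductase (Rattus norvegicus); on this read-out lower numbers stand for stronger inhibition and higher numbers for weaker inhibition:
Compound 1 `CCCCn1ccc2cc(/C(C)=C/C(=O)Nc3ccccc3OCCCC(=O)O)ccc21` gives 43 nM.
Compound 2 `CC(C)=CCn1ccc2cc(/C(C)=C/C(=O)Nc3ccccc3OCCCC(=O)O)ccc21` gives 120 nM.
Compound 3 `CCCC(C)n1ccc2cc(/C(C)=C/C(=O)Nc3ccccc3OCCCC(=O)O)ccc21` gives 7.8 nM.

Compound 3 holds the lowest number of the three, so it is the strongest inhibitor here: its nearest neighbour is compound 1, reached by the step of a 5.5-fold lower number from compound 1 to compound 3 (0.74 log units; beyond the scatter), and the furthest is compound 2, reached by a 15-fold lower number from compound 2 to compound 3 (1.19 log units; beyond the scatter). Both of these steps lie beyond the scatter. The third measured step, a 2.8-fold higher number from compound 1 to compound 2 (0.45 log units; beyond the scatter), reshaped the chain on the aromatic nitrogen in another way and cost a little potency.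

Compound 4 `CCCCC(C)n1ccc2cc(/C(C)=C/C(=O)Nc3ccccc3OCCCC(=O)O)ccc21` differs from compound 3 by methyl in place of hydrogen on a saturated chain carbon, four bonds along the chain from an aromatic nitrogen. Among the measured compounds shown here, no measured step adds a methyl at this place. The step from compound 1 to compound 3 added a methyl too, but on the carbon bound to the aromatic nitrogen, so it does not bear directly on a methyl placed four bonds further along the chain. With nothing closer to lean on, the expected change in this assay is small and in no certain direction, and the step of a 1.0-fold higher number from compound 3 to compound 4 (0.01 log units; within the scatter) is estimated to stay within the scatter. Compound 4 is therefore expected to give about 8 nM, most likely between 3 nM and 20 nM.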

Compound 4, half-maximal inhibitory concentration: 6 nM
For compound 4 the middle estimate is 1.3-fold (0.12 log units) above the measured one; low and high end bracket the measured number.
By their numbers in this assay, from the lowest: compounds 4 and 3 (each within the scatter of the next); then compound 1; then compound 2.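

In this assay the change from a 1-methylbutyl to a 1-methylpentyl chain on the aromatic nitrogen, which is a methyl in place of hydrogen four bonds along the chain, gives a 1.3-fold lower number from compound 3 to compound 4 (0.11 log units; within the scatter) and so makes no readable difference: this place on the chain accepts one more carbon without the inhibition being lost. The advantage of the branched chain over the other two chains therefore survives the extra carbon, with a 7.2-fold lower number from compound 1 to compound 4 (0.86 log units; beyond the scatter) against the butyl chain and a 20-fold lower number from compound 2 to compound 4 (1.30 log units; beyond the scatter) against the 3-methylbut-2-en-1-yl chain on the same core. Nothing here gives a measured reason why these chains rank as they do.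

On these data alone, how far this flat stretch goes remains open, since a longer chain such as 1-methylhexyl, or a chain carrying a hydroxyl group or an amine, could behave quite differently from a plain carbon chain. As far as these compounds go, it is also open whether the methyl on the carbon bound to the aromatic nitrogen could be replaced by an ethyl group and still give numbers like those of compound 3 and compound 4.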